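The source may report more compounds than this note shows. Statements on the series, on what has been measured and on what is new or still open speak of the compounds shown alone.

Three compounds share one core and differ only in the aromatic group carried on a saturated chain carbon bound to an amide-type nitrogen. Compound 1 `COc1ccc(CNC(=O)c2nc(-c3ccc(F)cc3)n(CC[C@@H](O)C[C@@H](O)CC(=O)O)c2C2CC2)cc1` gives 0.2 nM in a functional assay on cells (Hepatocyte, Rattus norvegicus) for inhibition, read by scintillation counting, with a stated time of 4 h; on this read-out higher numbers stand for weaker inhibition and lower numbers for stronger inhibition. Compound 2 `Cc1ccc(CNC(=O)c2nn(-c3ccc(F)cc3)c(CC[C@@H](O)C[C@@H](O)CC(=O)O)c2C(C)C)cc1` gives 0.9 nM in this assay. Compound 3 `Cc1cccc(CNC(=O)c2nc(-c3ccc(F)cc3)n(CC[C@@H](O)C[C@@H](O)CC(=O)O)c2C2CC2)c1` gives 0.3 nM in this assay. Among these three numbers compound 3 holds the second highest; compound 1 sits within the scatter of it, while compound 2 stands beyond the scatter with a higher number. For the measured compounds named here, the only measured step that bears on the next change is a 1.5-fold higher number from compound 1 to compound 3 (0.18 log units; within the scatter), so swapping one substituted aromatic ring for another at this place has so far moved the read-out little. Compound 4 `COc1ccccc1CNC(=O)c1nc(-c2ccc(F)cc2)n(CC[C@@H](O)C[C@@H](O)CC(=O)O)c1C1CC1` carries the change (2-methoxyphenyl in place of 3-methylphenyl on a saturated chain carbon bound to an amide-type nitrogen). Because a 1.5-fold higher number from compound 1 to compound 3 (0.18 log units; within the scatter) stayed within the scatter, a similarly small outcome is expected here, with no clear direction. Compound 4 is therefore estimated to give 0.3 nM, within a range from 0.1 nM to 0.9 nM. The expected step is no change at the digits printed from compound 3 to compound 4 (within the scatter).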

Compound 4, half-maximal inhibitory concentration: 0.1 nM
For compound 4 the middle estimate is 3.0-fold (0.48 log units) above the measured one; the measured number falls inside the stated range.
By their numbers in this assay, from the lowest: compounds 4, 1 and 3 (each within the scatter of the next, the first and the last beyond it); then compound 2.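

In this assay, for the compounds shown here, the step from 3-methylphenyl to 2-methoxyphenyl on a saturated chain carbon bound to an amide-type nitrogen gives a 3.0-fold lower number from compound 3 to compound 4 (0.48 log units; beyond the scatter) and is the first step at this place to pass beyond the scatter, so the read-out here does respond to the choice of substituted aromatic ring. The step from 4-methoxyphenyl to 2-methoxyphenyl, a 2.0-fold lower number from compound 1 to compound 4 (0.30 log units; within the scatter), stays within the scatter, so these two methoxy-bearing rings cannot be told apart on this read-out. Nothing in the data shown accounts for the larger step.

Still open, from the compounds shown here alone, is whether the lower number goes with the methoxy group or with its place on the ring, a question that 2-methylphenyl and 3-methoxyphenyl would help to separate. Also open, going by these compounds, is how plain phenyl, or a ring carrying an amine or a carboxylic acid, would read at this place.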